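A few compounds are considered here, and "the series" means these few. Any claim that something is new, unique, unknown or untested is made for them only; others in the source may bear on it.

Compounds measured in an assay on MDA-MB-231 cells for displacement of a labelled ligand from C-X-C chemokine receptor type 4 (Homo sapiens), read by fluorescence and microscopy, with stated times of 10 min and 30 min; on this read-out higher numbers stand for an effect only at larger amounts of compound and lower numbers for an effect already at smaller amounts:

compound 1, `O=C(NCc1ccc(CNS(=O)(=O)c2ccccc2F)cc1)c1cccnc1`: 100 nM
compound 2, `COc1ccccc1C(=O)NCc1ccc(CNS(=O)(=O)c2ccccc2F)cc1`: 1 nM
compound 3, `COc1ccccc1C(=O)NCc1ccc(CNS(=O)(=O)c2ccc(Cl)cc2)cc1`: 1000 nM

Compound 1 stands second highest of the three numbers in this assay. Its nearest neighbour is compound 3 with 1000 nM, its furthest is compound 2 with 1 nM; the step of a 100-fold lower number from compound 1 to compound 2 (2.00 log units; beyond the scatter) shows how far the amide end moves the read-out when 2-methoxyphenyl replaces pyridin-3-yl on the carbonyl carbon.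

Compound 4, `O=C(NCc1ccc(CNS(=O)(=O)c2ccc(F)cc2)cc1)c1cccnc1`, is not yet measured. It differs from compound 1 only at the sulfonyl end: 4-fluorophenyl in place of 2-fluorophenyl on a sulfonyl sulfur

Within the data shown here, the one measured step at the same place is a 1000-fold higher number from compound 2 to compound 3 (3.00 log units; beyond the scatter), where 4-chlorophenyl replaced 2-fluorophenyl on the sulfonyl sulfur. Among the measured compounds shown here, that step is not identical to the present one, since it brought in chlorine rather than fluorine and sat on the 2-methoxyphenyl series rather than the pyridin-3-yl series of compound 1, but it is the only guide to moving the halogen from the 2-position to the 4-position of the sulfonyl-bound ring. On that basis a higher number is expected for compound 4 in this assay, probably smaller than the step seen from compound 2 to compound 3, as a step of a 10-fold higher number from compound 1 to compound 4 (1.00 log units; beyond the scatter). Compound 4 is therefore estimated at 1000 nM, within 150 nM to 8000 nM.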

Compound 4, effective concentration (reported as EC, without a stated level of effect): 100 nM
Compound 4: the middle estimate sits 10-fold (1.00 log units) above what was measured; measured number outside the range, below it.
By their numbers in this assay, from the lowest: compound 2; then compounds 1 and 4 (each within the scatter of the next); then compound 3.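

In this assay, with pyridin-3-yl on the carbonyl carbon, 4-fluorophenyl in place of 2-fluorophenyl on the sulfonyl sulfur gives no change at the digits printed from compound 1 to compound 4 (within the scatter) and so shows that this position can take this exchange of rings without a measurable shift. Among these compounds, until now the only step at this place was a 1000-fold higher number from compound 2 to compound 3 (3.00 log units; beyond the scatter) in the series with 2-methoxyphenyl on the carbonyl carbon, and that step alone suggested a strong dependence on the ring at the sulfonyl sulfur. Among the compounds shown here, that dependence now cannot be taken as general for the series, since the one step at this place with pyridin-3-yl on the carbonyl carbon stays within the scatter.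

The compounds shown leave open whether the large step belongs to the chlorine or to the 2-methoxyphenyl series, a question that 4-fluorophenyl with 2-methoxyphenyl on the carbonyl carbon, or 4-chlorophenyl with pyridin-3-yl there, would settle. How 2-chlorophenyl or unsubstituted phenyl on the sulfonyl sulfur would read also stays open, and no measurement at hand accounts for the difference between the two steps.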